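Compound 4 and a series resting on an assay limit

The compounds below may be only part of what the source reports. "The series", "measured", "known", "first", "only" and "open" are said of these compounds alone.

Measured in a functional assay on MDA-MB-231 cells (Homo sapiens) for inhibition, read by MTT assay, with a stated time of 48 h; a lower number here means a stronger inhibitor, a higher number a weaker inhibitor:
compound 1 `CS(=O)(=O)c1ccc(-c2nc3ccccn3c2Sc2ccccc2)cc1`: 72700 nM
compound 2 `CCc1ccc(-c2nc3ccccn3c2Sc2ccccc2)cc1`: > 100000 nM (a limit)
compound 3 `Cc1ccc(-c2nc3ccccn3c2Sc2ccccc2)cc1`: > 100000 nM (a limit)

Compound 3 gives > 100000 nM in this assay, which is a limit of the assay and not a number. Most of this small set rests on (the limit of > 100000 nM in this assay, at which 2 of the 3 values shown sit).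

Compound 4 `C(=C/c1nc2ccccn2c1Sc1ccccc1)\c1ccccc1` keeps the shared core and its phenylsulfanyl group. The change is 2-phenylethenyl in place of 4-methylphenyl on an aromatic carbon, with 2-phenylethenyl in place of 4-methylphenyl on an aromatic carbon.

Among the measured compounds shown here, no measured step makes this exchange, so only edits to the group at that same place bear on it. These are an at least 1.3-fold higher number from compound 1 to compound 2 (0.13 log units; that floor lies within the scatter) and an at least 1.3-fold higher number from compound 1 to compound 3 (0.13 log units; that floor lies within the scatter), both floors within the scatter, and a step that the two limits leave unreadable from compound 2 to compound 3. None of them points in a clear direction, so no step beyond the scatter is expected in this assay, and compound 4 may well report only a limit.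

The estimated change is a number no higher from compound 3 to compound 4 (the limit leaves the size open).

For compound 4 the expected value is 100000 nM, with an estimated range from 45000 nM to 200000 nM.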

Compound 4, half-maximal inhibitory concentration: 25300 nM
Compound 4: the middle estimate sits 4.0-fold (0.60 log units) above what was measured; measured number below the stated range.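

In this assay, among the compounds shown here, putting 2-phenylethenyl at this place gives an at least 3.9-fold lower number from compound 3 to compound 4 (0.59 log units; beyond the scatter), and the same group gives an at least 3.9-fold lower number from compound 2 to compound 4 (0.59 log units; beyond the scatter); these are the first steps at this position that lie beyond the scatter. As far as these compounds go, their full sizes stay open because both start from an assay limit: the limit of > 100000 nM in this assay, at which 2 of the 4 values shown sit. The entering group keeps one six-membered aromatic ring of carbon only and adds a double bond outside aromatic rings, so the result belongs to the 2-phenylethenyl group as a whole and not to either part alone.

The compounds shown leave open whether the double bond is needed, which a saturated 2-phenylethyl group at this place would test. They also leave open how an amine or a carboxylic acid on the phenyl ring of the 2-phenylethenyl group would read in this assay.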